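A few compounds are considered here, and "the series" means these few. Any claim that something is new, unique, unknown or untested is made for them only; others in the source may bear on it.

Measured so far:
compound 1, `O=C(NOCc1ccccc1)c1cn(-c2ccccc2)nc1-c1ccccc1`: 122000 nM
compound 2, `O=C(NOCc1ccccc1Cl)c1cn(-c2ccccc2)nc1-c1ccccc1`: 82100 nM
compound 3, `COc1ccc(-c2nn(-c3ccccc3)cc2C(=O)NOCc2ccccc2Cl)cc1`: 586000 nM

These three compounds were tested in an ADME assay on HEK-293T cells (Homo sapiens) for antiproliferative activity, read by MTT assay, with a stated time of 48 h, in the presence of a further agent that is not named here; a higher number here means that more compound is tolerated, a lower number that less compound is tolerated. From compound 1 to compound 2 the change is chloro in place of hydrogen on an aromatic carbon, and in this assay it gave a 1.5-fold lower number from compound 1 to compound 2 (0.17 log units; within the scatter). Compound 3 carries a methoxy group instead, and in this assay a 7.1-fold higher number from compound 2 to compound 3 (0.85 log units; beyond the scatter). The difference between the core of compound 1 and the core of compound 3 is not broken down here.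

Compound 4, `COc1ccc(-c2nn(-c3ccccc3)cc2C(=O)NOCc2ccc(Cl)cc2Cl)cc1`, is not yet measured. It differs from compound 3 by chloro in place of hydrogen on an aromatic carbon. This is the same kind of change as that from compound 1 to compound 2, but here the entering chloro group sits meta to a chloro group and para to a large group, whereas before it sat ortho to a large group. Since the earlier step stayed within the scatter, the step from compound 3 to compound 4 in this assay is expected to be about a 1.3-fold lower number from compound 3 to compound 4 (0.11 log units; within the scatter). Compound 4 is thus estimated at 450000 nM, between 200000 nM and 1000000 nM.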

Compound 4, half-maximal cytotoxic concentration: 545000 nM
Compound 4: middle estimate off by 1.2-fold (0.08 log units), on the low side; measured number inside the range.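

In this assay, adding a second chloro group gave a 1.1-fold lower number from compound 3 to compound 4 (0.03 log units; within the scatter), and setting this beside the earlier case shows that the change did much the same on both cores: the same change on two cores in this assay, a 1.5-fold lower number (0.17 log units; within the scatter) from compound 1 to compound 2 and a 1.1-fold lower number (0.03 log units; within the scatter) from compound 3 to compound 4, 1.4-fold (0.14 log units) apart, within the scatter of two such steps

Within this series, then, replacing hydrogen with chloro on an aromatic carbon carried across the two cores without any step beyond the scatter. Going by these compounds alone, this rests on only two pairs, with the chloro group entering at a different place in each, so it shows no readable effect here, not that the same would hold on other cores or in other assays.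

The compounds shown leave open how this assay would respond to an amine or a carboxylic acid in place of the chloro group.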